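Ester to amide: what to expect for compound 4

The compounds below may be only part of what the source reports. "The series", "measured", "known", "first", "only" and "open" are said of these compounds alone.

Compound 1 `Cc1nc2ccccc2c(-c2ccccc2)c1C(=O)N(C)c1ccccc1`: > 10000 nM
Compound 2 `CCN(Cc1ccccc1)Cc1ccccc1C(=O)N(CC)CC`: 8210 nM
Compound 3 `CCOC(=O)c1c(CN(CC)Cc2ccccc2)nc2ccccc2c1-c1ccccc1`: 700 nM

All three were tested in an assay on brain with Translocator protein (Rattus norvegicus) as the target; on this read-out lower numbers stand for stronger inhibition and higher numbers for weaker inhibition. The result for compound 1 is a limit of the assay rather than a number, (the limit of > 10000 nM in this assay, at which 1 of the 3 values shown sits). Among the two numbers, compound 3 has the lowest, and the nearest number, that of compound 2, sits far enough above it to lie beyond the usual scatter. Compound 4 `CCN(Cc1ccccc1)Cc1nc2ccccc2c(-c2ccccc2)c1C(=O)N(C)C` differs from compound 3 only in one place: dimethylamino in place of ethoxy on a carbonyl carbon. Among the compounds with values here, no measured pair shows this exchange, so its effect is unknown; the step from compound 3 to compound 4 is expected to be a 1.4-fold higher number from compound 3 to compound 4 (0.15 log units; within the scatter), a modest change close to the scatter. Compound 4 is therefore estimated at 1000 nM, with a range from 150 nM to 6000 nM.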

Compound 4, half-maximal inhibitory concentration: 229 nM
The estimate for compound 4 lay 4.4-fold (0.64 log units) above the measured number, and the stated range covers the measured number.
By their numbers in this assay, from the lowest: compound 4; then compound 3; then compound 2. At a limit, above all of these: compound 1.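

On this carbonyl carbon, the ester can give way to an amide without loss in this assay: dimethylamino in place of ethoxy gives a 3.1-fold lower number from compound 3 to compound 4 (0.49 log units; beyond the scatter). The earlier compounds shown here offered no measured pair for this change, and here both groups carry 3 heavy atoms, so the exchange keeps that count while replacing oxygen with nitrogen. Nothing measured here explains the lower number.

On these data alone, whether a carboxylic acid or a longer chain such as dipropylamino on this carbonyl carbon would lower the number further remains open.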